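Truncating the side chain to a formyl group

A few compounds are considered here, and "the series" means these few. Any claim that something is new, unique, unknown or untested is made for them only; others in the source may bear on it.

Compound 1 `C=C1CC[C@@H]2[C@](C)(CO)[C@H](O)CC[C@@]2(C)[C@@H]1CCC1C(=O)OC[C@H]1O` is the starting point of the series. In an ADME assay on BMMC cells (Mus musculus, strain C57BL/6) for cytotoxicity, read by CCK-8 assay, with a stated time of 48 h, in the presence of a further agent that is not named here (a lower number here means that less compound is tolerated, a higher number that more compound is tolerated), compound 1 gives only a limit, > 30000 nM. Compound 2 `C=C1CC[C@@H]2[C@](C)(CO)[C@H](O)CC[C@@]2(C)[C@@H]1C/C=C1\C=COC1=O` carries a different five-membered ring on the same saturated chain carbon, and in this assay compound 2 gives 20600 nM. The resulting step, an at least 1.4-fold lower number from compound 1 to compound 2 (0.16 log units; that floor lies within the scatter), cannot be sized further because of the limit of > 30000 nM in this assay, at which 1 of the 2 values shown sits. Among the measured compounds shown here, compound 2 thus holds the only real number, the one further value being a limit.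

Compound 3 `C=C1CC[C@@H]2[C@](C)(CO)[C@H](O)CC[C@@]2(C)[C@@H]1CC=O` is not yet measured. The change from compound 2 is a group of 2 heavy atoms (1 carbon, 1 oxygen; no ring) in place of a group of 7 heavy atoms (5 carbon, 2 oxygen; one five-membered non-aromatic ring with 1 hetero atom), on a saturated chain carbon bound to a saturated ring carbon. For the measured compounds named here, the only measured step at this position is the one from compound 1 to compound 2, which lies within the scatter even at its floor, so it offers no direction for a further change on the same chain carbon. For this assay no step beyond the scatter is therefore expected from compound 2 to compound 3, and the estimated step is a 1.2-fold higher number from compound 2 to compound 3 (0.08 log units; within the scatter). Compound 3 is expected to give about 25000 nM, with a range from 10000 nM to 60000 nM.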

Compound 3, half-maximal cytotoxic concentration: > 30000 nM
Compound 3: only a limit was reported; the forecaster's own chance of this, stated with the estimate: 40%; at least 1.2-fold (0.07 log units) between middle value and limit.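

In this assay replacing the five-membered ring group with formyl gives an at least 1.4-fold higher number from compound 2 to compound 3 (0.16 log units; that floor lies within the scatter). Compound 3, like compound 1, gives only a limit, so two quite different groups on this saturated chain carbon, one with a ring and one without, now end the same way, and the ring of compound 2 is not required for a limit to appear at this position. The real size of the step to compound 3 remains unknown, and the step from compound 1 to compound 3 cannot be read, because both compounds give only a limit: the limit of > 30000 nM in this assay, at which 2 of the 3 values shown sit.

Among the compounds shown here, with compound 2 still the only compound holding a real number, the series shows no step at this position that is certain to lie beyond the scatter, so no direction of change can be assigned to the side chain. Also open, as far as these compounds go, is how a carboxylic acid, an amine or a longer chain in place of formyl on this chain carbon would read in this assay, and whether any of them would give a real number.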